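Furan Swapped for Methylsulfanyl: An Expected Flat Step

The source may hold more compounds than are shown below. What is called first, only, known or untested is meant among the compounds shown, and "the series" means these compounds.

Compound 1 `COC(=O)c1cccc(NC(=O)C2CCCN(C(=O)c3cc(C(F)(F)F)cc(C(F)(F)F)c3)C2)c1` gives 0% in an ADME assay on PC-3 cells (Homo sapiens) for cytotoxicity, read by WST assay, tested at 100 uM; on this read-out higher numbers stand for more inhibition at the one concentration tested (going by the name of the read-out) and lower numbers for less inhibition. Compound 2 `O=C(Nc1ccc(Cl)cc1)C1CCCN(C(=O)c2cccc(-c3ccco3)c2)C1` gives 0% in this assay, level with compound 1 within the scatter. Compound 3 `CSc1cccc(C(=O)N2CCCC(C(=O)Nc3ccc(Cl)cc3)C2)c1` has not yet been measured. Its difference from compound 2 is methylsulfanyl in place of furan-2-yl on an aromatic carbon. Within the data shown here, no measured pair shows what this change does on its own. Because compound 2 gives 0%, the step is expected to be none beyond the scatter, no change at the digits printed from compound 2 to compound 3 (within the scatter). Compound 3 is estimated at 0%, with a range from -8% to 12%.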

Compound 3, a percentage reported as inhibition, at one concentration (the size of the read-out at that concentration, not a potency): 0%
The estimate for compound 3 equals the measured number at the digits printed; the range from low to high includes it.
By their numbers in this assay, from the lowest: compounds 1, 2 and 3 (each within the scatter of the next).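

In this assay, among these compounds, replacing furan-2-yl with methylsulfanyl gives no change at the digits printed from compound 2 to compound 3 (within the scatter), the first comparison here of compounds that differ in one place. At this aromatic carbon, meta to a large group, the five-membered aromatic ring can thus give way to a group with no ring without any shift in the printed value. No measurement on hand bears on why this is so. On these data alone, whether an amine or a carboxylic acid at this position would move the read-out in this assay remains open. So does whether any change to the shared core would.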